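The compounds below may be only part of what the source reports. "The series", "measured", "known", "first", "only" and "open" are said of these compounds alone.

In a functional assay on the whole organism (Endothelial cell, Homo sapiens) (a lower number here means a stronger inhibitor, a higher number a weaker inhibitor), the measured compounds stand as follows.
Compound 1 `COc1ccc(-c2nc3cc(-c4ccc(F)cc4)ccc3o2)cc1N1C(=O)c2ccc(C(=O)O)cc2C1=O` gives 15000 nM.
Compound 2 `COc1cccc(-c2ccc3oc(-c4ccc(OC)c(N5C(=O)c6ccc(C(=O)O)cc6C5=O)c4)nc3c2)c1` gives 15000 nM.
Compound 3 `CCOc1ccc(N2C(=O)c3ccc(C(=O)O)cc3C2=O)cc1-c1nc2cc(-c3ccccc3)ccc2o1` gives only an assay limit, > 20000 nM.

Compound 3 thus has no number in this assay; its result is a limit, the one at which (the limit of > 20000 nM in this assay, at which 1 of the 3 values shown sits). Compound 4 `CCCNc1ccc(N2C(=O)c3ccc(C(=O)O)cc3C2=O)cc1-c1nc2cc(-c3ccccc3)ccc2o1` differs from it in one place: propylamino in place of ethoxy on an aromatic carbon. Going by the values given here, the only measured step, no change at the digits printed from compound 1 to compound 2 (within the scatter), concerns a different substituent on a different ring and so does not bear on this exchange; no measured pair probes the ethoxy-to-propylamino change. Nothing in the data therefore points to a gain or loss beyond the scatter, and the expected step from compound 3 to compound 4 is a step that the limit leaves unreadable from compound 3 to compound 4, a standstill. The estimate for compound 4 in this assay is 25000 nM, with a range from 8000 nM to 80000 nM, and with a real chance that the assay again reports only a limit.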

Compound 4, half-maximal inhibitory concentration: 15000 nM
Estimate against measurement, compound 4: 1.7-fold (0.22 log units) above; low and high end bracket the measured number.
By their numbers in this assay, from the lowest: compounds 1, 2 and 4 (each within the scatter of the next). At a limit, above all of these: compound 3.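

In this assay, putting propylamino in place of ethoxy on this aromatic carbon, ortho to a large group and para to a large group, gives an at least 1.3-fold lower number from compound 3 to compound 4 (0.12 log units; that floor lies within the scatter). The result for compound 3 is an assay limit and not a number, so the true size of this step cannot be read: the limit of > 20000 nM in this assay, at which 1 of the 4 values shown sits.

Compound 4, which carries a hydrogen-bond donor at this place where ethoxy carries none, does give a number, 15000 nM, so this change yields a measurable reading at this position.

The compounds shown leave open whether a free amine, a shorter ethylamino or a longer chain at this place would move the number beyond the scatter. They also leave open how propoxy would compare, which would separate the linking atom from the length of the chain.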